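The source may hold more compounds than are shown below. What is called first, only, known or untested is meant among the compounds shown, and "the series" means these compounds.

Two compounds share one core and differ only in the aryl group attached to it. Compound 1 `CC(=O)c1ccc(-c2cn3ccnc3c(-c3ccc4ncn(C5CCCCC5)c4c3)n2)cc1` gives 7.12% in a functional assay on NCI-H460 cells (Homo sapiens) for inhibition, read by sulforhodamine B assay, with a stated time of 48 h, tested at 10 uM; on this read-out higher numbers stand for more inhibition at the one concentration tested (going by the name of the read-out) and lower numbers for less inhibition. Compound 2 `COc1ccccc1-c1cn2ccnc2c(-c2ccc3ncn(C4CCCCC4)c3c2)n1` gives 9.62% in this assay, which is the higher of the two numbers, yet the step of a number 2.5 percentage points higher from compound 1 to compound 2 (within the scatter) lies within the scatter, so the two are not told apart. Compound 3 `FC(F)(F)c1cccc(-c2cn3ccnc3c(-c3ccc4ncn(C5CCCCC5)c4c3)n2)c1` has not been measured. It differs from compound 2 in this way: 3-(trifluoromethyl)phenyl in place of 2-methoxyphenyl on an aromatic carbon. Among the measured compounds shown here, the one measured step, a number 2.5 percentage points higher from compound 1 to compound 2 (within the scatter), is the step that bears on this change: it too exchanged one aryl group for another at the same place, and it stayed within the scatter. A change of the same kind is therefore expected to move the number by no more than the scatter, in no particular direction. For compound 3 the estimate is 8%, within 0% to 22%, which means an expected step of a number 1.6 percentage points lower from compound 2 to compound 3 (within the scatter).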

Compound 3, a percentage reported as inhibition, at one concentration (the size of the read-out at that concentration, not a potency): 4.38%
For compound 3 the middle estimate is 3.6 percentage points above the measured one, and the stated range covers the measured number.
By their numbers in this assay, from the lowest: compounds 3, 1 and 2 (each within the scatter of the next).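

In this assay, the new aryl group gives a number 5.2 percentage points lower from compound 2 to compound 3 (within the scatter) and a number 2.7 percentage points lower from compound 1 to compound 3 (within the scatter), so 3-(trifluoromethyl)phenyl cannot be told apart from either 2-methoxyphenyl or 4-acetylphenyl at this position. The entering group has no hydrogen-bond acceptor and the 2-methoxyphenyl it replaces has one, yet this exchange stays within the scatter, so three different aryl groups now give numbers that cannot be separated. Nothing available here explains why these compounds read alike.

The compounds shown leave open whether any group at this position can raise the inhibition beyond the scatter. From the compounds shown here alone, an aryl ring carrying an amine or a carboxylic acid, or a longer chain in place of the ring, would test this, and the rest of the shared core remains unexplored here.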